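From Fluoro and Trifluoromethyl to Chloro on the Aromatic Ring

The compounds below may be only part of what the source reports. "The series", "measured", "known", "first", "only" and "open" are said of these compounds alone.

Compound 1 `COc1cc(NC(C)CCCNC(=O)NNC(=O)Nc2ccc(Cl)cc2)c2ncccc2c1` gives 120000 nM
Compound 2 `COc1cc(NC(C)CCCNC(=O)Nc2ccc(F)cc2)c2ncccc2c1` gives 20000 nM
Compound 3 `COc1cc(NC(C)CCCNC(=O)Nc2ccc(C(F)(F)F)cc2)c2ncccc2c1` gives 8300 nM

In a functional assay on HeLa cells (Homo sapiens) for inhibition, read by MTT assay, with a stated time of 72 h (on this read-out lower numbers stand for stronger inhibition and higher numbers for weaker inhibition), compound 3 gives 8300 nM and this is the lowest of the three numbers. Compound 4 `COc1cc(NC(C)CCCNC(=O)Nc2ccc(Cl)cc2)c2ncccc2c1` carries chloro in place of trifluoromethyl on an aromatic carbon and nothing else changes. Going by the values given here, the one measured step at this aromatic carbon, trifluoromethyl in place of fluoro, is a 2.4-fold lower number from compound 2 to compound 3 (0.38 log units; beyond the scatter) and it is modest. The steps of a 6.0-fold lower number from compound 1 to compound 2 (0.78 log units; beyond the scatter) and a 14-fold lower number from compound 1 to compound 3 (1.16 log units; beyond the scatter) are larger, but they replace a group at a different place and bear little on this change. A slight rise is therefore expected, with the estimated step of a 1.4-fold higher number from compound 3 to compound 4 (0.16 log units; within the scatter) and so none beyond the scatter. Compound 4 is estimated at 12000 nM within an expected range of 6000 nM to 25000 nM.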

Compound 4, half-maximal inhibitory concentration: 18000 nM
The estimate for compound 4 lay 1.5-fold (0.18 log units) below the measured number; low and high end bracket the measured number.
By their numbers in this assay, from the lowest: compound 3; then compounds 4 and 2 (each within the scatter of the next); then compound 1.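

In this assay, trifluoromethyl stands apart from the two halogens at this aromatic carbon (a 2.2-fold higher number from compound 3 to compound 4 (0.34 log units; beyond the scatter)), while chloro and fluoro cannot be told apart (a 1.1-fold lower number from compound 2 to compound 4 (0.05 log units; within the scatter)). With chloro on the aromatic ring of both compounds, the change at the amide-type nitrogen can be read without a change of ring group (a 6.7-fold lower number from compound 1 to compound 4 (0.82 log units; beyond the scatter)). Nothing given here explains these differences.

The compounds shown leave open whether a methoxy or a nitrile at this aromatic carbon would match the halogens or trifluoromethyl. They also leave open what an amine or a carboxylic acid there would do.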